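Replacing Fluoro with an Aminoalkyl Chain on Compound 1

This account rests on a few compounds, and the source may have more. Where it says the series, first, only, none or still open, it means among the compounds named here.

Measured compounds:
Compound 1, `COc1cc(F)c(NC(=O)c2cnccn2)cc1Nc1nccc(-c2cn(C)c3ccccc23)n1`, gives 24800 nM in a functional assay on NCI-H1975 cells (Homo sapiens) for antiproliferative activity, read by MTT assay, with a stated time of 72 h; on this read-out lower numbers stand for stronger inhibition and higher numbers for weaker inhibition.
Compound 2, `COc1cc(F)c(NC(=O)c2ncccn2)cc1Nc1nccc(-c2cn(C)c3ccccc23)n1`, gives 13500 nM in this assay.

Among the measured compounds shown here, compound 1 stands at the highest of the two numbers so far; its nearest neighbour is compound 2, and the step of a 1.8-fold lower number from compound 1 to compound 2 (0.26 log units; within the scatter) is within the scatter, so the two are not told apart. Compound 3, `COc1cc(N(C)CCN(C)C)c(NC(=O)c2cnccn2)cc1Nc1nccc(-c2cn(C)c3ccccc23)n1`, has not yet been measured in this assay. It differs from compound 1 by a single change, ((2-(dimethylamino)ethyl)(methyl)amino in place of fluoro on an aromatic carbon).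

For the measured compounds named here, no measured step bears on this change. Going by the values given here, the only step in hand, from compound 1 to compound 2, concerns the ring on the carbonyl carbon and leaves the fluoro untouched, so it says nothing about what the new chain will do. With nothing to anchor the direction, the estimate for compound 3 can only be a guess with a wide range. Compound 3 is expected to give 3000 nM, with a plausible range from 300 nM to 30000 nM. This estimate corresponds to a step of an 8.3-fold lower number from compound 1 to compound 3 (0.92 log units; beyond the scatter), a direction taken on no measured evidence.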

Compound 3, half-maximal inhibitory concentration: 1220 nM
The estimate for compound 3 lay 2.5-fold (0.39 log units) above the measured number; the range from low to high includes it.
By their numbers in this assay, from the lowest: compound 3; then compounds 2 and 1 (each within the scatter of the next).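

The position para to a large group, ortho to a ((pyrazin-2-yl)carbonyl)amino group and meta to a methoxy group proves sensitive in this assay: placing (2-(dimethylamino)ethyl)(methyl)amino there in place of fluoro gives a large step (a 20-fold lower number from compound 1 to compound 3 (1.31 log units; beyond the scatter)). Among the compounds shown here, the earlier compounds could not show this, as their one step lay at the ring on the carbonyl carbon, left the fluoro untouched and stayed within the scatter. Nothing at hand explains why this exchange of a single fluorine for the open chain has so large an effect.

The compounds shown leave open which part of the chain carries the step: the terminal dimethylamino group, the methylamino nitrogen on the aromatic carbon, or the length of the chain, questions that a shorter or longer chain, a terminal hydroxyl group or a 4-methylpiperazin-1-yl ring could help to separate. As far as these compounds go, it also remains open whether the same chain would give a step of similar size on compound 2, which carries pyrimidin-2-yl on the carbonyl carbon.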